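Methoxy for trifluoromethyl on the benzyl of compound 2

A few compounds are considered here, and "the series" means these few. Any claim that something is new, unique, unknown or untested is made for them only; others in the source may bear on it.

Two compounds of the series have numbers in a functional assay on HeLa cells (Homo sapiens) for antiproliferative activity, read by sulforhodamine B assay, with a stated time of 48 h (a higher number here means a weaker inhibitor of growth, a lower number a stronger inhibitor of growth), so far. Compound 1 `COc1ccc(Cn2cc(CNC(=O)c3cn(-c4ccccc4)nc3-c3ccccc3)nn2)cc1` gives 6900 nM in this assay. Compound 2 `O=C(NCc1cn(Cc2ccc(C(F)(F)F)cc2)nn1)c1cn(-c2ccccc2)nc1-c1ccc(Cl)cc1` gives 1900 nM in this assay, the lower of the two numbers; the gap from compound 1 to compound 2 lies beyond the scatter of repeated measurements, so compound 2 stands as the stronger growth inhibitor of the pair. Within the data shown here, compound 1 and compound 2 differ in two places at once, and no single-point step between measured compounds exists, so neither change can be read on its own from these two values.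

Compound 3 `COc1ccc(Cn2cc(CNC(=O)c3cn(-c4ccccc4)nc3-c3ccc(Cl)cc3)nn2)cc1` is not yet measured in this assay. It differs from compound 2 in one place: methoxy in place of trifluoromethyl on an aromatic carbon. Compound 3 thus carries the methoxybenzyl of compound 1 together with the chlorophenyl of compound 2. Among the measured compounds shown here, with no step of this kind measured, the expected change from compound 2 to compound 3 is small, a 1.6-fold higher number from compound 2 to compound 3 (0.20 log units; within the scatter), toward a somewhat higher number or none beyond the scatter. For compound 3 the expected value in this assay is 3000 nM, with a range from 1200 nM to 8000 nM.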

Compound 3, concentration for 50% growth inhibition: 1400 nM
The estimate for compound 3 lay 2.1-fold (0.33 log units) above the measured number; low and high end bracket the measured number.
By their numbers in this assay, from the lowest: compounds 3 and 2 (each within the scatter of the next); then compound 1.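

In this assay, methoxy in place of trifluoromethyl on the aromatic carbon para to a large group gives a 1.4-fold lower number from compound 2 to compound 3 (0.13 log units; within the scatter), so with the chlorophenyl held constant, these two groups cannot be told apart at this position, despite differing in size and in hydrogen-bond acceptor count. The series also now has its first readable step at the other site: with the 4-methoxybenzyl held constant, chloro in place of hydrogen on an aromatic carbon gives a 4.9-fold lower number from compound 1 to compound 3 (0.69 log units; beyond the scatter), a modest gain that lies beyond the scatter and is the only change among the compounds shown with a readable effect on growth inhibition. Nothing available here bears on the reason for the size of either step.

The compounds shown leave open whether the chloro step carries over to the 4-(trifluoromethyl)benzyl side, and so whether the two sites act independently of each other. Also open, on these data alone, is how this position responds to groups of another kind, such as a carboxylic acid or an amine, and whether a plain benzyl with hydrogen at that carbon would fit with methoxy and trifluoromethyl.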